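Hydroxylated amides on an alkyne-linked scaffold

This account rests on a few compounds, and the source may have more. Where it says the series, first, only, none or still open, it means among the compounds named here.

Measured compounds:
compound 1, `COc1ccc(C#Cc2ccc(C(=O)N3CCC[C@@H](O)C3)cc2F)cc1`: in a functional assay on HEK293 cells for negative allosteric modulation of metabotropic glutamate receptor 2 (Rattus norvegicus), read by calcium flux, with a stated time of 2.5 min (a higher number here means a weaker inhibitor, a lower number a stronger inhibitor), compound 1 gives > 30000 nM, which is a limit of the assay rather than a number.
compound 2, `COc1ccc(C#Cc2ccc(C(=O)N3CC4CCC(=O)C4C3)cc2)cc1`: in this assay compound 2 gives > 30000 nM, again a limit and not a number.
compound 3, `COc1ccc(C#Cc2ccc(C(=O)N3CCC[C@@H](O)C3)c(F)c2)cc1`: in this assay compound 3 gives > 30000 nM, also only a limit.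

Among the measured compounds shown here, compound 2 therefore stands where every other value here stands, at the limit of > 30000 nM in this assay, at which 3 of the 3 values shown sit; no compound in this set has yielded a number, so compound 2 can be placed neither above nor below its companions.

Compound 4, `COc1ccc(C#Cc2ccc(C(=O)N3CC[C@H](O)C3)cc2)cc1`, has not been measured. It differs from compound 2 in a single place: a group of 6 heavy atoms (4 carbon, 1 nitrogen, 1 oxygen; one five-membered non-aromatic ring with 1 hetero atom) in place of a group of 9 heavy atoms (7 carbon, 1 nitrogen, 1 oxygen; one five-membered non-aromatic ring of carbon only, one five-membered non-aromatic ring with 1 hetero atom), on a carbonyl carbon. For the measured compounds named here, with no measured pair of compounds that differ in one place, there is no step of known size to lean on. Going by the values given here, the only guide is that compound 1 and compound 3, which also carry a hydroxylated ring amide on the shared core, sit at the same limit. The expectation is thus that compound 4 will again fall at or near the limit, and the step of a number no higher from compound 2 to compound 4 (the limit leaves the size open) is estimated to be none beyond the scatter. For compound 4 the estimate is 30000 nM, with a range from 6000 nM to 100000 nM.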

Compound 4, half-maximal inhibitory concentration: > 30000 nM
Compound 4: no number, only a limit; the forecaster's own chance of this, stated with the estimate: 75%; the middle value sits exactly at the limit.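

Compound 2 and compound 4 each give only a limit, not a number, so no step can be read between them: the limit of > 30000 nM in this assay, at which 4 of the 4 values shown sit. The compounds shown leave open which change on the shared core, if any, would give an actual number in this assay.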